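Chromone dithiocarbamates: dropping the chloro substituent

The source may report more compounds than this note shows. Statements on the series, on what has been measured and on what is new or still open speak of the compounds shown alone.

Measured so far:
compound 1, `O=c1cc(CSC(=S)N2CCCCC2)oc2ccccc12`, 13700 nM
compound 2, `O=c1cc(CSC(=S)N2CCOCC2)oc2cc(Cl)ccc12`, a limit only

In a functional assay on SW480 cells (Homo sapiens) for antiproliferative activity, read by MTT assay, with a stated time of 72 h (on this read-out lower numbers stand for stronger inhibition and higher numbers for weaker inhibition), compound 1 gives 13700 nM. In this assay compound 2 gives only a limit, > 25000 nM. That is the limit of > 25000 nM in this assay, at which 1 of the 2 values shown sits. Compound 3, `O=c1cc(CSC(=S)N2CCOCC2)oc2ccccc12`, differs from compound 2 by hydrogen in place of chloro on an aromatic carbon. Within the data shown here, no measured pair isolates this change; compound 1 and compound 2 differ in two places, and their values show only that both are weak. The expected step of an at least 1.1-fold lower number from compound 2 to compound 3 (0.05 log units; that floor lies within the scatter) is small, within the scatter, with no set direction. Compound 3 is expected near 22000 nM, between 8000 nM and 60000 nM.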

Compound 3, half-maximal inhibitory concentration: 24400 nM
Estimate against measurement, compound 3: 1.1-fold (0.04 log units) below; measured number inside the range.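

Hydrogen in place of chloro on this aromatic carbon reads in this assay as an at least 1.0-fold lower number from compound 2 to compound 3 (0.01 log units; that floor lies within the scatter) and that is a floor, not a size. Compound 2 holds only a limit, so the chloro effect at this position stays unsized: the limit of > 25000 nM in this assay, at which 1 of the 3 values shown sits. Morpholin-4-yl in place of piperidin-1-yl on the thiocarbonyl carbon gives a 1.8-fold higher number from compound 1 to compound 3 (0.25 log units; within the scatter) and so does not separate these two rings.

On these data alone, whether any substituent on this aromatic carbon changes the number remains open, for example methoxy or fluoro. As far as these compounds go, an open-chain amine such as diethylamino on the thiocarbonyl carbon is also open.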